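Quinazoline thioacetamides: anilino ring change, compound 4

The source may hold more compounds than are shown below. What is called first, only, known or untested is meant among the compounds shown, and "the series" means these compounds.

Measured compounds in a functional assay on PC-3 cells (Homo sapiens) for inhibition, read by MTT assay, with a stated time of 72 h; a lower number here means a stronger inhibitor, a higher number a weaker inhibitor:
compound 1 `O=C(CSc1nc(Nc2ccccc2)c2ccccc2n1)Nc1ccc(Br)cc1` — 8450 nM
compound 2 `O=C(CSc1nc(Nc2ccccc2)c2ccccc2n1)Nc1ccc(C(F)(F)F)cc1` — 10400 nM
compound 3 `C=CC(=O)Nc1cccc(NC(=O)CSc2nc(Nc3ccccc3Cl)c3ccccc3n2)c1` — 14400 nM

All three numbers lie close together. For the measured compounds named here, the one step recorded between compounds that differ in one place, a 1.2-fold higher number from compound 1 to compound 2 (0.09 log units; within the scatter), is within the scatter and concerns the ring attached to the amide nitrogen, not the ring on the anilino nitrogen. Compound 3 sits within the scatter of both compound 1 and compound 2 in this assay; nothing in the series separates it from them.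

Compound 4 `C=CC(=O)Nc1cccc(NC(=O)CSc2nc(Nc3ccc(F)cc3)c3ccccc3n2)c1` differs from compound 3 in one place: 4-fluorophenyl in place of 2-chlorophenyl on a nitrogen on an aromatic ring. Going by the values given here, no measured step touches this ring, so there is no direct precedent. Among the compounds with values here, the only available step, from compound 1 to compound 2, shows that exchanging one halogen-type substituent for another on an aryl ring left this assay unchanged; that is weak, indirect support for expecting no movement here either. The estimated step of a 1.2-fold lower number from compound 3 to compound 4 (0.08 log units; within the scatter) is therefore expected to stay within the scatter. Compound 4 is expected to give about 12000 nM in this assay, with a range of 5000 nM to 30000 nM.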

Compound 4, half-maximal inhibitory concentration: 8240 nM
For compound 4 the middle estimate is 1.5-fold (0.16 log units) above the measured one; measured number inside the range.
By their numbers in this assay, from the lowest: compounds 4, 1, 2 and 3 (each within the scatter of the next).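

For the compounds shown here, compound 3 and compound 4 give the first reading on the aryl group carried by this nitrogen in this assay. In that reading, a 1.7-fold lower number from compound 3 to compound 4 (0.24 log units; within the scatter) stays within the scatter, so 4-fluorophenyl and 2-chlorophenyl cannot be told apart at this place. The three compounds with a halogen on an aromatic ring at one of the two varied sites therefore add no separation to the series, and this step changes the halogen and its printed ring position together, so neither can be read alone.

Still open, on these data alone, is whether an aryl group bearing an amine, a carboxylic acid or a methoxy group on this nitrogen would move the number beyond the scatter. No measured property is available to explain this result.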